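Swapping Methoxy for Chloro on the Phenyl Ring

The source may hold more compounds than are shown below. What is called first, only, known or untested is meant among the compounds shown, and "the series" means these compounds.

Of the compounds shown here, two sharing one core have been tested in a functional assay on HOP-92 cells (Homo sapiens) for inhibition; on this read-out lower numbers stand for stronger inhibition of growth and higher numbers for weaker inhibition of growth. Compound 1 `COc1cc(/C=C/C(=O)c2cccc(-n3cc(-c4ccccc4)[nH]c3=O)c2)ccc1O` gives 2270 nM. Compound 2 `COc1ccc(-c2cn(-c3cccc(C(=O)/C=C/c4ccc(O)c(OC)c4)c3)c(=O)[nH]2)cc1` gives 2960 nM, numerically the highest of the two values, though the step of a 1.3-fold higher number from compound 1 to compound 2 (0.12 log units; within the scatter) means the two cannot really be told apart. Compound 3 `COc1cc(/C=C/C(=O)c2cccc(-n3cc(-c4ccc(Cl)cc4)[nH]c3=O)c2)ccc1O` differs from compound 2 by chloro in place of methoxy on an aromatic carbon. Among the compounds with values here, no measured step covers this exchange directly; the single step known, from hydrogen to methoxy, was small, so there is no ground for expecting a large shift. Compound 3 is therefore expected to give 2500 nM, between 1000 nM and 6500 nM. The expected step is a 1.2-fold lower number from compound 2 to compound 3 (0.07 log units; within the scatter).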

Compound 3, concentration for 50% growth inhibition: 1260 nM
Compound 3: middle estimate off by 2.0-fold (0.30 log units), on the high side; measured number inside the range.
By their numbers in this assay, from the lowest: compounds 3, 1 and 2 (each within the scatter of the next, the first and the last beyond it).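

In this assay, the group para to a large group does make a readable difference: chloro in place of methoxy gives a 2.3-fold lower number from compound 2 to compound 3 (0.37 log units; beyond the scatter), a modest step, but the first here beyond the scatter. Chloro in place of hydrogen gives a 1.8-fold lower number from compound 1 to compound 3 (0.26 log units; within the scatter), so only the 4-methoxyphenyl and 4-chlorophenyl compounds can be told apart, while the compound with hydrogen there cannot be separated from either. Nothing available explains why these two groups differ. As far as these compounds go, whether an amine or a carboxylic acid at this position would shift the number further remains open.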